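The source may hold more compounds than are shown below. What is called first, only, known or untested is meant among the compounds shown, and "the series" means these compounds.

Working notes on the series, in an ADME assay on L1210/0 cells (Mus musculus) for cytotoxicity, with a stated time of 48 h; a lower number here means a stronger inhibitor, a higher number a weaker inhibitor.

Among the compounds with values here, compound 1 `O=C(CI)NCc1cn([C@H]2C[C@H](O)[C@@H](CO)O2)c(=O)[nH]c1=O` is the only compound in the set with a numerical reading: in this assay compound 1 gives 107000 nM. Compound 2 `OC[C@H]1C[C@@H](Cn2cnc3c(NC4CC4)ncnc32)c2ccccc21` is the other member, and compound 2 returns only a limit of the assay, > 200000 nM, so it cannot be placed against compound 1 beyond noting that one of the two values sits at the limit of > 200000 nM in this assay, at which 1 of the 2 values shown sits. Within the data shown here, compound 1 therefore stands alone as the one measured number, and it is a weak inhibitor on the scale of this assay.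

Compound 3 `O=c1[nH]c(=O)n([C@H]2C[C@H](O)[C@@H](CO)O2)cc1C#Cc1ccccc1` has not yet been measured. It differs from compound 1 in one place: 2-phenylethynyl in place of (((iodomethyl)carbonyl)amino)methyl on an aromatic carbon. Among the measured compounds shown here, no measured pair in the set spans a comparable change, so no step size can be taken from the data.

The expectation for compound 3 is a reading near that of compound 1, within the scatter or at most a small shift toward weaker inhibition, that is a step of a 1.4-fold higher number from compound 1 to compound 3 (0.15 log units; within the scatter). Compound 3 is estimated at 150000 nM, with a plausible range from 40000 nM to 400000 nM. A fair chance remains that compound 3 is reported only as a limit, as compound 2 was.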

Compound 3, half-maximal inhibitory concentration: > 200000 nM
Compound 3: only a limit was reported; the forecaster's own chance of this, stated with the estimate: 40%; middle value at least 1.3-fold (0.12 log units) away from the limit.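

In this assay, putting 2-phenylethynyl in place of (((iodomethyl)carbonyl)amino)methyl on this aromatic carbon gives an at least 1.8-fold higher number from compound 1 to compound 3 (0.27 log units; that floor lies within the scatter), which is a floor and not a measured size of step. Compound 3 is reported as > 200000 nM, a limit of the assay and not a number. The change therefore shows that this carbon can carry an all-carbon group with no iodine, no nitrogen and no oxygen and still give no numerical reading, but it does not establish a difference beyond the scatter, and compound 1 remains the only compound with a number: the limit of > 200000 nM in this assay, at which 2 of the 3 values shown sit.

As far as these compounds go, how far compound 3 actually lies from compound 1 stays open, as does whether the iodine or the amide of the (((iodomethyl)carbonyl)amino)methyl group has any bearing on the reading of compound 1. A plain acetylaminomethyl group without iodine, or a simple aminomethyl or a carboxylic acid on the same carbon, would separate those two parts of the group and might give further numbers below the limit.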